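A few compounds are considered here, and "the series" means these few. Any claim that something is new, unique, unknown or untested is made for them only; others in the source may bear on it.

Measured compounds:
compound 1 `CCCCCCCCOC1CC(=O)Nc2c1c(C)nn2-c1ncnc2nc[nH]c12` – in a functional assay on HEK293 cells for agonist activity at G-protein coupled receptor 39 (Homo sapiens), read by scintillation proximity assay and inositol phosphate accumulation, with a stated time of 75 min (on this read-out lower numbers stand for an effect already at smaller amounts and higher numbers for an effect only at larger amounts of compound), compound 1 gives 388 nM
compound 2 `Cc1nn(-c2ncnc3nc[nH]c23)c2c1C(OCc1ccc(C(C)C)cc1)CC(=O)N2` – compound 2 gives 1690 nM
compound 3 `Cc1nn(-c2ncnc3nc[nH]c23)c2c1C(OCc1ccc(C#N)cc1)CC(=O)N2` – compound 3 gives 60 nM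

Compound 3 stands at the lowest number of the three; the step of a 6.5-fold lower number from compound 1 to compound 3 (0.81 log units; beyond the scatter) and the step of a 28-fold lower number from compound 2 to compound 3 (1.45 log units; beyond the scatter) both lie beyond the scatter, so compound 3 is the most potent of the measured set. Compound 4 `Cc1nn(-c2ncnc3nc[nH]c23)c2c1C(OCc1ccc(F)cc1)CC(=O)N2` is not yet measured. It differs from compound 3 by fluoro in place of cyano on an aromatic carbon.

The step that bears most directly on this change is a 28-fold lower number from compound 2 to compound 3 (1.45 log units; beyond the scatter), which shows that the substituent on that aromatic ring matters greatly. The steps of a 4.4-fold higher number from compound 1 to compound 2 (0.64 log units; beyond the scatter) and a 6.5-fold lower number from compound 1 to compound 3 (0.81 log units; beyond the scatter) place the cyano compound on one side and the isopropyl compound on the other side of the heptyl compound. Fluoro is a different substituent from either, so no measured step gives it directly; the expectation is a modest rise in the number, within the span set by compound 2 and compound 3. Compound 4 is therefore estimated at 200 nM, with a range of 60 nM to 700 nM, meaning an expected step of a 3.3-fold higher number from compound 3 to compound 4 (0.52 log units; beyond the scatter).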

Compound 4, half-maximal effective concentration: 126 nM
The estimate for compound 4 lay 1.6-fold (0.20 log units) above the measured number; low and high end bracket the measured number.
By their numbers in this assay, from the lowest: compound 3; then compound 4; then compound 1; then compound 2.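

In this assay, fluoro in place of cyano gives a 2.1-fold higher number from compound 3 to compound 4 (0.32 log units; beyond the scatter), so this position on the aromatic ring tolerates a change from cyano to a substituent of a single heavy atom with a measurable but limited rise in the number. The 4-fluorobenzyl group also improves on heptyl, with a 3.1-fold lower number from compound 1 to compound 4 (0.49 log units; beyond the scatter) as the step, and on 4-isopropylbenzyl, with a 13-fold lower number from compound 2 to compound 4 (1.13 log units; beyond the scatter) as the step, so the large rise seen with isopropyl does not extend to every replacement of cyano. No data here give a reason for these differences.

Still open, going by these compounds, is how methoxy, chloro or trifluoromethyl would rank at this position against fluoro and cyano. Also open, on these data alone, is whether an amine or a carboxylic acid would be accepted there.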